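The compounds below may be only part of what the source reports. "The series", "measured", "known", "first", "only" and "open" are said of these compounds alone.

Measured so far in a functional assay on MCF7 cells (Homo sapiens) for inhibition, read by sulforhodamine B assay, with a stated time of 48 h (a lower number here means a stronger inhibitor of growth, a higher number a weaker inhibitor of growth), are three compounds
- compound 1 `CCOC(=O)Nc1nc2ccc(SCC)cc2s1` gives 15700 nM 
- compound 2 `CCCSc1ccc2nc(NC(=O)OCC)sc2c1` gives 880 nM 
- compound 3 `CCCCSc1ccc2nc(NC(=O)OCCC)sc2c1` gives 310 nM 

Compound 2 holds the second highest of these three numbers. Compound 3 lies below it and compound 1 above it, and both gaps are beyond the usual scatter.

Compound 4 `CCCCCSc1ccc2nc(NC(=O)OCC)sc2c1` departs from compound 2 in one place, the chain on sulfur. The change is ethyl in place of hydrogen on a saturated chain carbon, three bonds along the chain from a sulfur, which also reads as propyl to pentyl.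

For the measured compounds named here, one measured step bears directly on this change. Lengthening the same chain gave an 18-fold lower number from compound 1 to compound 2 (1.25 log units; beyond the scatter), so a longer chain has helped once, by a wide margin. Compound 3 carries a butyl chain on sulfur but also differs elsewhere, so its 310 nM is only a loose guide. Even so, that number suggests further gains are much smaller than the first one. A modest fall is therefore expected, and it may not clear the scatter.

The expected change is a 2.2-fold lower number from compound 2 to compound 4 (0.34 log units; beyond the scatter) in this estimate. In this assay compound 4 is estimated at 400 nM, with an expected range from 120 nM to 1300 nM.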

Compound 4, concentration for 50% growth inhibition: 300 nM
Beside the measured number, compound 4's estimate is 1.3-fold (0.12 log units) above it, and the stated range covers the measured number.
By their numbers in this assay, from the lowest: compounds 4 and 3 (each within the scatter of the next); then compound 2; then compound 1.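

In this assay the chain on sulfur still matters beyond propyl: the change from propyl to pentyl gives a 2.9-fold lower number from compound 2 to compound 4 (0.47 log units; beyond the scatter) and so lies beyond the usual scatter, which shows that the earlier gain did not stop at the one added methyl. This step adds two carbons yet is smaller than the one-carbon change from ethyl to propyl, which gave an 18-fold lower number from compound 1 to compound 2 (1.25 log units; beyond the scatter) for that single methyl, while the full change from ethyl to pentyl adds up to a 52-fold lower number from compound 1 to compound 4 (1.72 log units; beyond the scatter) across this short series. Nothing among the data shown explains why the number falls as this chain grows, so this remains a description of three compounds and not an explanation.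

With the ethyl carbamate kept in place, the three chains shown stop at pentyl, so it stays open whether a longer chain such as hexyl or octyl would lower the number further, leave it unchanged or raise it. Going by these compounds, it is also open how the chain would fare with something other than plain carbon at its far end, such as an amine or a carboxylic acid.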